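Biphenyl amide: diethylamino in place of methoxybenzylamino

This account rests on a few compounds, and the source may have more. Where it says the series, first, only, none or still open, it means among the compounds named here.

Of the compounds shown here, three built on one shared core have been measured. In a functional assay (Pituitary gland cell) with Rattus norvegicus as the target (on this read-out higher numbers stand for an effect only at larger amounts of compound and lower numbers for an effect already at smaller amounts), compound 1 `CCNC(=O)c1ccccc1-c1ccc(CN2C(=O)[C@H](NC(=O)CC(C)(C)N)CCc3ccccc32)cc1` gives 0.09 uM, compound 3 `CC(C)(N)CC(=O)N[C@@H]1CCc2ccccc2N(Cc2ccc(-c3ccccc3C(=O)NCc3ccc(O)cc3)cc2)C1=O` gives 0.3 uM, and compound 2 `COc1ccc(CNC(=O)c2ccccc2-c2ccc(CN3C(=O)[C@H](NC(=O)CC(C)(C)N)CCc4ccccc43)cc2)cc1` gives 2 uM, the highest number of the three. Compound 4 `CCN(CC)C(=O)c1ccccc1-c1ccc(CN2C(=O)[C@H](NC(=O)CC(C)(C)N)CCc3ccccc32)cc1` differs from compound 2 by diethylamino in place of (4-methoxybenzyl)amino on a carbonyl carbon. The closest guide is a 22-fold higher number from compound 1 to compound 2 (1.35 log units; beyond the scatter), because compound 4, like compound 1, carries only short chains on that nitrogen; a 3.3-fold higher number from compound 1 to compound 3 (0.52 log units; beyond the scatter) points the same way. For the measured compounds named here, the loss of the amide hydrogen in compound 4 has no measured counterpart. A large move toward compound 1 is nonetheless expected, a 6.7-fold lower number from compound 2 to compound 4 (0.82 log units; beyond the scatter), so the estimate for compound 4 in this assay is 0.3 uM, with a range from 0.05 uM to 2 uM.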

Compound 4, concentration for half-maximal effect: 2 uM
Estimate against measurement, compound 4: 6.7-fold (0.82 log units) below, and the stated range covers the measured number.
By their numbers in this assay, from the lowest: compound 1; then compound 3; then compounds 2 and 4 (each within the scatter of the next).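

In this assay the exchange of (4-methoxybenzyl)amino for diethylamino brings no change at the digits printed from compound 2 to compound 4 (within the scatter) so removing the aromatic ring from this carbonyl carbon does not by itself give a lower number. A single added ethyl on the amide-type nitrogen brings a 22-fold higher number from compound 1 to compound 4 (1.35 log units; beyond the scatter) and the exchange of (4-hydroxybenzyl)amino for diethylamino brings a 6.7-fold higher number from compound 3 to compound 4 (0.82 log units; beyond the scatter) so keeping the amide hydrogen goes with the lower numbers here, though compound 2 keeps it and goes against this. No measurement at hand explains these steps.

Going by these compounds, whether the number follows the lost amide hydrogen or the added ethyl stays open. Dimethylamino or a pyrrolidine ring on this carbonyl carbon could help separate the two.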